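The source may hold more compounds than are shown below. What is called first, only, known or untested is meant among the compounds shown, and "the series" means these compounds.

Working notes on the series. In an ADME assay on cells (Astrocyte, Homo sapiens) for cytotoxicity, read by WST assay, with a stated time of 72 h (on this read-out higher numbers stand for weaker inhibition and lower numbers for stronger inhibition), compound 1 (`O=C(Nc1ccc(C(F)(F)F)cc1)Nc1cc2ncncc2cc1OCc1cccc(F)c1`) gives 8900 nM and compound 2 (`O=C(Nc1cc2ncncc2cc1OCc1ccc(F)cc1)Nc1cccc2ccccc12`) gives 8500 nM while compound 3 (`O=C(Nc1ccc(Cl)c(Cl)c1)Nc1cc2ncncc2cc1OCc1cccc(F)c1`) gives 7400 nM on the same read-out. These three numbers lie within the scatter of one another, so compound 3 has no separate standing among them.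

Compound 4 (`O=C(Nc1cc2ncncc2cc1OCc1cccc(F)c1)Nc1cccc2ccccc12`) has naphthalen-1-yl in place of 3,4-dichlorophenyl on an amide-type nitrogen and remains to be measured. Within the data shown here, the one measured step at this place is a 1.2-fold lower number from compound 1 to compound 3 (0.08 log units; within the scatter) for 3,4-dichlorophenyl in place of 4-(trifluoromethyl)phenyl, and it stays within the scatter. Compound 2 also carries naphthalen-1-yl on an amide-type nitrogen and gives 8500 nM in this comparison, but it differs from compound 4 elsewhere in the structure. Among the measured compounds shown here, no measured pair isolates naphthalen-1-yl against 3,4-dichlorophenyl.

In this assay no step beyond the scatter is therefore expected, and no direction can be argued from these numbers. The estimated step is a 1.1-fold higher number from compound 3 to compound 4 (0.03 log units; within the scatter) and it is expected to stay inside the scatter. For compound 4 the estimated value is 8000 nM with an expected range from 5000 nM to 13000 nM on this read-out.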

Compound 4, half-maximal inhibitory concentration: > 10000 nM
Compound 4: only a limit was reported; the forecaster's own chance of this, stated with the estimate: 15%; middle value at least 1.2-fold (0.09 log units) from the limit.
By their numbers in this assay, from the lowest: compounds 3, 2 and 1 (each within the scatter of the next). At a limit, above all of these: compound 4.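

Compound 4 gives a limit of the read-out and not a number: the limit of > 10000 nM in this assay, at which 1 of the 4 values shown sits.

In this assay, among these compounds, the first measured pairs that isolate naphthalen-1-yl on an amide-type nitrogen give an at least 1.3-fold higher number from compound 3 to compound 4 (0.13 log units; that floor lies within the scatter) against 3,4-dichlorophenyl and an at least 1.1-fold higher number from compound 1 to compound 4 (0.05 log units; that floor lies within the scatter) against 4-(trifluoromethyl)phenyl, while the fluorine change on the other side of the molecule, 3-fluorophenyl in place of 4-fluorophenyl, gives an at least 1.1-fold higher number from compound 2 to compound 4 (0.07 log units; that floor lies within the scatter). Each of these steps is only a floor, and each floor lies within the scatter, so none of the three changes is established as a real shift, though none is shown to be absent.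

The size of all three steps stays open, since compound 4 has no number to set against the others, and nothing shown separates a contribution from naphthalen-1-yl from the reach of the read-out. Also open, on these data alone, is how a carboxylic acid or an amine would read in place of these aromatic groups on an amide-type nitrogen.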